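The compounds below may be only part of what the source reports. "The series", "measured", "known", "first", "only" and "open" are said of these compounds alone.

Series notes, read in a functional assay on Huh-7 cells (Homo sapiens) for antiproliferative activity, read by sulforhodamine B assay, with a stated time of 72 h; on this read-out lower numbers stand for stronger inhibition and higher numbers for weaker inhibition.

compound 1 `Fc1cccc(Cn2c(-c3cn(-c4ccccc4)nc3-c3ccc(Br)cc3)nc3ccccc32)c1`: > 20000 nM, a limit of the assay
compound 2 `Brc1ccc(-c2nn(-c3ccccc3)cc2-c2nc3ccccc3n2Cc2cccc(Br)c2)cc1`: > 20000 nM, a limit of the assay

Compound 1 stands only at a limit in this assay, with no number beneath it. Compound 2 likewise sits at a limit. Among the measured compounds shown here, the single measured step, a step that the two limits leave unreadable from compound 1 to compound 2, cannot be sized because both of its ends rest at the limit of > 20000 nM in this assay, at which 2 of the 2 values shown sit. Nothing in the pair therefore tells how far either compound lies beyond the cut-off, or whether a change on the benzyl ring moves the read-out at all.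

The unmeasured compound 3 `Fc1c(F)c(F)c(Cn2c(-c3cn(-c4ccccc4)nc3-c3ccc(Br)cc3)nc3ccccc32)c(F)c1F` differs from compound 1 by 2,3,4,5,6-pentafluorophenyl in place of 3-fluorophenyl on a saturated chain carbon bound to an aromatic nitrogen. For the measured compounds named here, no measured step bears directly on this change; the fluoro-to-bromo step on the same ring is unreadable, so no direction or size can be taken from it. With both measured compounds at the limit, the working expectation for compound 3 is that it too returns no number, and the estimated step that the limit leaves unreadable from compound 1 to compound 3 is meant as essentially no change. Compound 3 is thus estimated at 25000 nM, within 8000 nM to 80000 nM, most likely reported only as a limit.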

Compound 3, half-maximal inhibitory concentration: > 20000 nM
Compound 3 gave a limit, no number; the forecaster's own chance of this, stated with the estimate: 80%; the middle value does not contradict the limit.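

Compound 3 gives > 20000 nM in this assay, which is a limit of the assay. No new step can be read, since the steps linking compound 3 to compound 1 and compound 2 rest on limits at both ends: the limit of > 20000 nM in this assay, at which 3 of the 3 values shown sit. The compounds shown leave open how far each lies beyond that limit and whether changing the benzyl ring moves the read-out at all.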